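The compounds below may be only part of what the source reports. "The series", "measured", "known", "first", "only" and "open" are said of these compounds alone.

Measured in a functional assay on HeLa cells (Homo sapiens) for cytotoxicity, read by CCK-8 assay; on this read-out lower numbers stand for stronger inhibition and higher numbers for weaker inhibition:

- Compound 1 `COc1ccc(NC(=O)c2ncc(-c3cc(OC)c(OC)c(OC)c3)o2)cc1`: 20500 nM
- Compound 2 `O=C(Nc1ccc(O)cc1)c1ncc(-c2ccc(F)cc2)o1`: > 30000 nM, a limit of the assay
- Compound 3 `O=C(Nc1cccc(O)c1)c1ncc(-c2ccccc2)o1`: > 30000 nM, a limit of the assay

Compound 1 is the only one of the three with an actual number. Compound 3 stands at > 30000 nM, and this is a limit, not a number. Compound 2 shares that position, so the series shows (the limit of > 30000 nM in this assay, at which 2 of the 3 values shown sit).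

Compound 4 `Cc1ccc(NC(=O)c2ncc(-c3ccccc3)o2)cc1` has not yet been measured. It keeps the core of compound 3 but carries 4-methylphenyl in place of 3-hydroxyphenyl on an amide-type nitrogen. Among the measured compounds shown here, no measured pair of compounds differs in just one place, so nothing here gives this change a size. The estimated step of a number no higher from compound 3 to compound 4 (the limit leaves the size open) is therefore rough, with no clear direction and nothing beyond the usual scatter expected. In this assay, compound 4 is expected at about 30000 nM, with an estimated range of 12000 nM to 60000 nM.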

Compound 4, half-maximal inhibitory concentration: > 30000 nM
Compound 4: no number, only a limit; the forecaster's own chance of this, stated with the estimate: 65%; the middle value lies on the limit itself.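

Among the compounds shown here, compound 3 and compound 4 both stop at a limit of the assay rather than a number, so no step between them can be read: (the limit of > 30000 nM in this assay, at which 3 of the 4 values shown sit). The compounds shown leave open how strongly compound 3 and compound 4 act in this assay and whether 4-methylphenyl in place of 3-hydroxyphenyl on an amide-type nitrogen changes this at all.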